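Adding a methyl to the anticonvulsant amide scaffold

The compounds below may be only part of what the source reports. "The series", "measured", "known", "first", "only" and "open" are said of these compounds alone.

Of the compounds shown here, two have been tested so far in a functional assay on the whole organism (Hindlimb, strain albino) with Mus musculus as the target, in the maximal electroshock model, with a stated time of 0.5 h; a lower number here means that less compound is needed, a higher number that more compound is needed for the effect. Compound 1 `COc1ccc(/C=C/C(=O)Nc2nc3ccc(C)cc3s2)cc1` gives 209 umol/kg. Compound 2 `O=C(/C=C/c1ccccc1)Nc1nc2ccccc2s1` gives 646 umol/kg, the highest of the two numbers; compound 1 is its nearest neighbour, and the gap between them lies beyond the usual scatter of this assay. Among the measured compounds shown here, no pair of measured compounds differs in only one place, so no single step can yet be read off directly.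

Compound 3 `Cc1ccc2nc(NC(=O)/C=C/c3ccccc3)sc2c1` is the next to be measured. Compared with compound 2 it carries the change (methyl in place of hydrogen on an aromatic carbon). Since compound 1, which also bears a methyl on its core, shows the lower number, a moderate move in the same direction is expected for compound 3, a step of about a 1.8-fold lower number from compound 2 to compound 3 (0.27 log units; within the scatter). Compound 3 is therefore estimated at 350 umol/kg, with a likely range from 160 umol/kg to 780 umol/kg.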

Compound 3, dose for half-maximal effect: 380 umol/kg
Beside the measured number, compound 3's estimate is 1.1-fold (0.04 log units) below it, within the range that was stated.
By their numbers in this assay, from the lowest: compounds 1, 3 and 2 (each within the scatter of the next, the first and the last beyond it).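

Among the compounds shown here, this is the first direct reading of methyl in place of hydrogen on an aromatic carbon of the shared core: in this assay, the change gives a 1.7-fold lower number from compound 2 to compound 3 (0.23 log units; within the scatter), so its effect cannot be told apart from the variation between repeated measurements. Hydrogen in place of methoxy on an aromatic carbon gives a 1.8-fold higher number from compound 1 to compound 3 (0.26 log units; within the scatter), so that single change is likewise unresolved in this assay. Nothing available offers an explanation for either step.

As far as these compounds go, it remains open whether an ethyl group, a chlorine atom or an amine at the methyl position would give a step beyond the scatter. From the compounds shown here alone, it is also open whether a methyl on another carbon of the same ring would give a step of similar size.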